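The source may report more compounds than this note shows. Statements on the series, on what has been measured and on what is new or still open speak of the compounds shown alone.

Three compounds, compound 1 `CS(=O)(=O)c1ccc(C(=O)NCC(=O)N(Cc2ccccc2)Cc2ccccc2)cc1[N+](=O)[O-]`, compound 2 `CN(CC(=O)N(Cc1ccccc1)Cc1ccccc1)C(=O)c1ccc(S(C)(=O)=O)c([N+](=O)[O-])c1` and compound 3 `CN(CC(=O)N1CCc2ccccc2C1)C(=O)c1ccc(S(C)(=O)=O)c([N+](=O)[O-])c1`, were tested in an assay on isolated protein for inhibition of vitamin D3 receptor (Homo sapiens), read by fluorescence polarization; on this read-out higher numbers stand for weaker inhibition and lower numbers for stronger inhibition. In this assay compound 1 gives only a limit, > 60000 nM. Compound 2 likewise gives only a limit, > 60000 nM. Compound 3 also gives only a limit, > 60000 nM. Because all three values sit at the limit of > 60000 nM in this assay, at which 3 of the 3 values shown sit, the step that the two limits leave unreadable from compound 2 to compound 1 cannot be read. That step is hydrogen in place of methyl on an amide-type nitrogen. Compound 4 `CS(=O)(=O)c1ccc(C(=O)NCC(=O)N2CCc3ccccc3C2)cc1[N+](=O)[O-]` is not yet measured; it arises from compound 3 by the same change, (hydrogen in place of methyl on an amide-type nitrogen). The difference between the cores of compound 2 and compound 3 is not broken down here. The step from compound 3 to compound 4 is expected to be a number no higher from compound 3 to compound 4 (the limit leaves the size open), because the matching step that the two limits leave unreadable from compound 2 to compound 1 left both compounds at the limit. Compound 4 is therefore estimated at 60000 nM, between 30000 nM and 60000 nM.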

Compound 4, half-maximal inhibitory concentration: 50000 nM
Compound 4: middle estimate off by 1.2-fold (0.08 log units), on the high side, within the range that was stated.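

In this assay, going by these compounds, hydrogen in place of methyl on an amide-type nitrogen gives an at least 1.2-fold lower number from compound 3 to compound 4 (0.07 log units; that floor lies within the scatter), a floor only, since the value of compound 3 is a limit and the true size stays open. This shows that the change yields a readable number on the core of compound 3, but it does not show that the change carries over from one core to the other or that its size is shared. The matching step on the core of compound 1 cannot be read, because compound 1 and compound 2 both sit at a limit: the limit of > 60000 nM in this assay, at which 3 of the 4 values shown sit.

The compounds shown leave open how a longer chain such as ethyl would read in place of the methyl on that nitrogen. They also leave open how an amine or a carboxylic acid would read in place of the nitro group.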